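The source may report more compounds than this note shows. Statements on the series, on what has been measured and on what is new or still open speak of the compounds shown alone.

Three compounds have been measured in a functional assay on HCT-116 cells (Homo sapiens) for inhibition, read by sulforhodamine B assay, with a stated time of 48 h, tested at 10 uM; on this read-out higher numbers stand for a weaker effect at the one concentration tested and lower numbers for a stronger effect:

compound 1, `COc1cc(Cl)cc(-c2nn(-c3cccc(NC(=O)c4ccc(Cl)c(Cl)c4)c3)cc2-c2ccncc2)c1`, gives 44.1%
compound 2, `O=C(Nc1cccc(-n2cc(-c3ccncc3)c(-c3cc(O)cc(Cl)c3)n2)c1)Nc1ccc(Cl)c(C(F)(F)F)c1`, gives 6.95%
compound 3, `COc1cc(Cl)cc(-c2nn(-c3cccc(NC(=O)Nc4cc(C(F)(F)F)cc(C(F)(F)F)c4)c3)cc2-c2ccncc2)c1`, gives -4.6%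

On these numbers compound 3 stands lowest of the three. Its nearest neighbour is compound 2, whose number is higher by a gap beyond the usual scatter; compound 1 lies furthest away, its number higher by a gap well beyond the scatter. Among the three, compound 3 thus shows the strongest effect at the single concentration tested, with compound 2 close behind and compound 1 clearly weaker.

The next compound, compound 4, `COc1cc(Cl)cc(-c2nn(-c3cccc(NC(=O)Nc4cccc(C(F)(F)F)c4)c3)cc2-c2ccncc2)c1`, differs from compound 3 in one place: hydrogen in place of trifluoromethyl on an aromatic carbon. Going by the values given here, no pair of measured compounds that differ in a single place is available, so the size of such a step has not been observed here. In this assay a step from compound 3 to compound 4 is expected to run toward a higher number, of modest size and plausibly beyond the scatter, because compound 3 already stands at -4.6% and leaves little room in the other direction. Compound 4 is therefore estimated to give 15%, within a range from -5% to 45%. This estimate means an expected step of a number 19.6 percentage points higher from compound 3 to compound 4 (beyond the scatter).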

Compound 4, a percentage reported as activity, at one concentration (the size of the read-out at that concentration, not a potency): 5.07%
Beside the measured number, compound 4's estimate is 9.9 percentage points above it; measured number inside the range.
By their numbers in this assay, from the lowest: compounds 3, 4 and 2 (each within the scatter of the next, the first and the last beyond it); then compound 1.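

In this assay, the first step read at a single place, a number 9.7 percentage points higher from compound 3 to compound 4 (within the scatter), lies within the scatter, so at this place on the aromatic ring, meta to a trifluoromethyl group, hydrogen in place of trifluoromethyl leaves no readable change at the one concentration tested. The second step, a number 39 percentage points lower from compound 1 to compound 4 (beyond the scatter), lies beyond the scatter and is large, which shows that (3-(trifluoromethyl)phenyl)amino in place of 3,4-dichlorophenyl on the carbonyl carbon matters far more on this read-out than the loss of the trifluoromethyl group. No measurement at hand accounts for either step.

Going by these compounds, it remains open whether the trifluoromethyl group that stays in compound 4 can also give way to hydrogen, and whether a methoxy group, a carboxylic acid or an amine at the place that changed would leave the number where it stands. The larger step also exchanges the linking amino group and the ring substituents together, so a 3,4-dichlorophenylamino group on the same carbonyl carbon would be needed to tell these two parts apart.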